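Notes on a small series and one untested analogue

This account rests on a few compounds, and the source may have more. Where it says the series, first, only, none or still open, it means among the compounds named here.

Values in an assay on NIH3T3 cells for displacement of a labelled ligand from melatonin receptor type 1B (Homo sapiens), with a stated time of 90 min; a higher number here means a weaker inhibitor, a lower number a stronger inhibitor:

compound 1 `COc1ccccc1OC(C)CNC(C)=O` — 5130 nM
compound 2 `CC(=O)NCC(C)Oc1ccccc1` — 1150 nM
compound 3 `CC(=O)NCCSc1ccccc1` — 339 nM

Compound 3 gives the lowest number of the three; compound 2 lies higher and compound 1 higher still, both gaps beyond the scatter. The difference between the cores of compound 2 and compound 3 is not broken down here. From compound 2 to compound 1 the change is methoxy in place of hydrogen on an aromatic carbon and gives a 4.5-fold higher number from compound 2 to compound 1 (0.65 log units; beyond the scatter).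

Compound 4 `COc1ccccc1SCCNC(C)=O` is not yet measured in this assay. Against compound 3 it carries methoxy in place of hydrogen on an aromatic carbon, the same kind of change: the place differs only in that the group it is ortho to counts 7 heavy atoms rather than 8. The expected step is a 3.8-fold higher number from compound 3 to compound 4 (0.58 log units; beyond the scatter), resting on the measured step of a 4.5-fold higher number from compound 2 to compound 1 (0.65 log units; beyond the scatter). For compound 4 the estimate in this assay is 1300 nM, likely between 500 nM and 4000 nM.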

Compound 4, inhibition constant: 501 nM
Compound 4: middle estimate off by 2.6-fold (0.41 log units), on the high side, within the range that was stated.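

In this assay the methoxy change gives a 1.5-fold higher number from compound 3 to compound 4 (0.17 log units; within the scatter), a step that stays within the scatter on this core. The same change therefore does not carry over at the same size from one core to the other: the same change on two cores in this assay, a 4.5-fold higher number (0.65 log units; beyond the scatter) from compound 2 to compound 1 and a 1.5-fold higher number (0.17 log units; within the scatter) from compound 3 to compound 4, 3.0-fold (0.48 log units) apart, beyond the scatter of two such steps. This shows that, for these two pairs, the size of the step differs with the core; it does not show which feature of the cores is responsible, and two pairs give no rule for any further core.

Open, as far as these compounds go, is how a chlorine or a hydroxyl in place of the same hydrogen would behave on the two cores. Also open, from the compounds shown here alone, is whether a longer chain between the ring and the amide would change the step.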